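The source may hold more compounds than are shown below. What is called first, only, known or untested is meant among the compounds shown, and "the series" means these compounds.

Compound 1 `Cc1cc(C#N)cc(C)c1Oc1nc(NC2CCCN(Cc3ccc(C(N)=O)cc3)C2)nc2ccsc12`: 19500 nM
Compound 2 `Cc1cc(C#N)cc(C)c1Oc1nc(NC2CCC(NCc3ccc(C(N)=O)cc3)CC2)nc2ccsc12`: 7720 nM

Both numbers come from an ADME assay on MT4 cells (Homo sapiens) for cytotoxicity, read by MTT assay, with a stated time of 5 days; a lower number here means that less compound is tolerated, a higher number that more compound is tolerated. Within the data shown here, of the two, compound 2 gives the lower number, meaning that less of it is tolerated by the cells; the only other number, that of compound 1, is higher by a step that lies beyond the usual scatter of this assay. Among the measured compounds shown here, the two compounds differ in the ring that links the shared core to the benzyl group, and no single-point step between them is available, so only the two values themselves can be compared.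

Compound 3 `Cc1cc(C#N)cc(C)c1Oc1nc(NC2CCC(NCc3ccc([N+](=O)[O-])cc3)CC2)nc2ccsc12` differs from compound 2 in one place: nitro in place of carbamoyl on an aromatic carbon of the six-membered ring at the end of the molecule. For the measured compounds named here, no measured pair shows this change, so there is no step to lean on. For this reason the step of a 1.1-fold lower number from compound 2 to compound 3 (0.04 log units; within the scatter) is expected to stay within the scatter, in no clear direction. Compound 3 is therefore estimated at 7000 nM, with a range from 2500 nM to 20000 nM.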

Compound 3, half-maximal cytotoxic concentration: 54400 nM
For compound 3 the middle estimate is 7.8-fold (0.89 log units) below the measured one; measured number outside the range, above it.
By their numbers in this assay, from the lowest: compound 2; then compound 1; then compound 3.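

In this assay, putting nitro in place of carbamoyl, on the aromatic carbon para to a large group, gives a 7.0-fold higher number from compound 2 to compound 3 (0.85 log units; beyond the scatter). Among these compounds, compound 1 and compound 2 differ only in the ring that links the shared core to the benzyl group, so this pair is the first to show that the end of the molecule also matters: a single change there moves the number by more than the usual scatter. The two groups have the same count of heavy atoms and differ in what they offer for hydrogen bonds, with 1 donor in carbamoyl and 0 in nitro, but no measurement here explains the step.

One pair cannot tell whether this step belongs to nitro alone or whether another group at the same place, such as a carboxylic acid or an amine, would also raise the number. It also leaves open whether 4-nitrobenzyl in place of 4-carbamoylbenzyl would have a similar effect on the linking ring of compound 1.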